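Ester-to-acid step in a diaryl ketone series

This account rests on a few compounds, and the source may have more. Where it says the series, first, only, none or still open, it means among the compounds named here.

Measured so far:
compound 1, `NC(=O)c1ccc2ccc(C(=O)c3ccccc3)c-2cc1`, 18%
compound 2, `COC(=O)c1cccc2c(C(=O)c3ccccc3)cc(C(=O)c3ccc(C(Cl)(Cl)Cl)cc3)c-2c1`, 27%

Two compounds have been run in an assay on cells for displacement of a labelled ligand from Orexin receptor type 2 (Homo sapiens), read by scintillation counting, with stated times of 10 min and 90 min, tested at 10 uM; a higher number here means more inhibition at the concentration tested (going by the name of the read-out), a lower number less inhibition. Compound 1 gives 18%, and compound 2 gives 27%. Compound 2 holds the higher of the two numbers, but its nearest neighbour, compound 1, lies within the scatter of it, so no order between them can be read. Among the compounds with values here, no pair of measured compounds differs in one place, so no measured step exists to lean on.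

Compound 3, `O=C(O)c1cccc2c(C(=O)c3ccccc3)cc(C(=O)c3ccc(C(Cl)(Cl)Cl)cc3)c-2c1`, is the next compound. It differs from compound 2 as follows: hydrogen in place of methyl on an oxygen next to a carbonyl group. Read one bond further out, methoxycarbonyl becomes carboxy.

Within the data shown here, with no measured step of this kind, the expectation is a change no larger than the scatter, with at most a slight downward drift, which is the step of a number 5 percentage points lower from compound 2 to compound 3 (within the scatter). Compound 3 is estimated at 22%, with a range from 5% to 45%.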

Compound 3, a percentage reported as inhibition, at one concentration (the size of the read-out at that concentration, not a potency): 25.6%
The estimate for compound 3 lay 3.6 percentage points below the measured number; measured number inside the range.
By their numbers in this assay, from the lowest: compounds 1, 3 and 2 (each within the scatter of the next).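

Within the data shown here, at this position, the change from methoxycarbonyl to carboxy gives a number 1.4 percentage points lower from compound 2 to compound 3 (within the scatter) in this assay, the first comparison between compounds that differ in one place. Hydrogen can therefore stand in place of methyl on this oxygen without a change that can be read beyond the scatter, at the one concentration tested. Nothing on hand accounts for this result.

The compounds shown leave open whether a hydroxymethyl or an aminomethyl group in place of carboxy would move the number beyond the scatter. Also open, going by these compounds, is whether the same change from methoxycarbonyl to carboxy would read alike on a compound carrying a methyl or a fluorine in place of the trichloromethyl group.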